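The source may hold more compounds than are shown below. What is called first, only, known or untested is meant among the compounds shown, and "the series" means these compounds.

Measured compounds in the set:

- compound 1, `CC1(C)C[C@@H](CN([C@H](CCC(F)(F)F)C(N)=O)S(=O)(=O)c2ccc(Cl)cc2)O1`: 14.9 10^-6 cm/s
- compound 2, `CC1(C)CO[C@@H]1CN([C@H](CCC(F)(F)F)C(N)=O)S(=O)(=O)c1ccc(Cl)cc1`: 22.3 10^-6 cm/s
- compound 3, `NC(=O)[C@@H](CCC(F)(F)F)N(C[C@H]1COCCO1)S(=O)(=O)c1ccc(Cl)cc1`: 20.6 10^-6 cm/s

All three share one core and differ only in the ring carried on the saturated chain carbon bound to the sulfonamide nitrogen. In an ADME assay on MDCKII-LE cells (Canis lupus familiaris) for permeability, read by transwell migration, in the apical to basolateral direction (on this read-out lower numbers stand for lower permeability and higher numbers for higher permeability), compound 2 gives 22.3 10^-6 cm/s. The step of a 1.5-fold higher number from compound 1 to compound 2 (0.18 log units; within the scatter) and the step of a 1.1-fold lower number from compound 2 to compound 3 (0.03 log units; within the scatter) are both within the scatter, so compound 2 cannot be separated from compound 1 or compound 3 on these numbers; the remaining pair, a 1.4-fold higher number from compound 1 to compound 3 (0.14 log units; within the scatter), is likewise within the scatter.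

Compound 4, `NC(=O)[C@@H](CCC(F)(F)F)N(C[C@@H]1CCOC1)S(=O)(=O)c1ccc(Cl)cc1`, is not yet measured. Relative to compound 2 the change is oxolan-3-yl in place of 3,3-dimethyloxetan-2-yl on a saturated chain carbon bound to a sulfonamide nitrogen

The three measured steps all bear on this change, since each swaps one small oxygen-containing ring for another at the same place, and none of them moved this assay beyond the scatter. The same is therefore expected here: no step beyond the scatter, in either direction.

For compound 4 the expectation in this assay is 20 10^-6 cm/s, with a range of 11 10^-6 cm/s to 38 10^-6 cm/s, which means an expected step of a 1.1-fold lower number from compound 2 to compound 4 (0.05 log units; within the scatter).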

Compound 4, apparent permeability: 20.5 10^-6 cm/s
Estimate against measurement, compound 4: 1.0-fold (0.01 log units) below; the range from low to high includes it.
By their numbers in this assay, from the lowest: compounds 1, 4, 3 and 2 (each within the scatter of the next).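

At the saturated chain carbon bound to a sulfonamide nitrogen, the series now includes oxolan-3-yl, a five-membered non-aromatic ring with 1 hetero atom and no dimethyl substitution, and in this assay this change gives a 1.1-fold lower number from compound 2 to compound 4 (0.04 log units; within the scatter), a 1.0-fold lower number from compound 3 to compound 4 (0.00 log units; within the scatter) and a 1.4-fold higher number from compound 1 to compound 4 (0.14 log units; within the scatter). The earlier compounds shown here compared the two dimethyloxetanyl isomers and 1,4-dioxan-2-yl; the new steps add a five-membered ring with 1 hetero atom to that comparison, and all four groups still cannot be separated on this read-out. No measurement here accounts for this flat behaviour.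

As far as these compounds go, all four groups are neutral rings containing oxygen and bearing no hydrogen-bond donor, so it remains open whether a basic amine such as piperidin-4-yl, a carboxylic acid, or an all-carbon group such as cyclohexyl or a longer alkyl chain would stay within the scatter at this place. From the compounds shown here alone, the other stereoisomer of oxolan-3-yl also remains open, as does whether the same flat picture would hold with a different group in place of the 4-chlorophenyl on the sulfonyl.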